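Ethoxy for methyl on the pyridyl arm of compound 2

This account rests on a few compounds, and the source may have more. Where it says the series, first, only, none or still open, it means among the compounds named here.

Compound 2 `COc1ccccc1-n1nc(C2CC(C)(C)OC(C)(C)C2)cc1-c1ccc(C)nc1` shows the highest number of the two compounds measured in an assay on HEK293 cells for inhibition of Voltage-dependent N-type calcium channel subunit alpha-1B (Homo sapiens), read by patch clamp, using a membrane potential dye; a lower number here means a stronger inhibitor, a higher number a weaker inhibitor: compound 2 gives 13000 nM, while compound 1 `CCOc1ccc(-c2cc(C3CC(C)(C)OC(C)(C)C3)nn2-c2ccccc2OC)cc1` gives 29 nM. Among the measured compounds shown here, the single measured step, a 450-fold higher number from compound 1 to compound 2 (2.65 log units; beyond the scatter), came from exchanging the 4-ethoxyphenyl arm of compound 1 for the 6-methylpyridin-3-yl arm of compound 2.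

Compound 3 `CCOc1ccc(-c2cc(C3CC(C)(C)OC(C)(C)C3)nn2-c2ccccc2OC)cn1` differs from compound 2 in one place: ethoxy in place of methyl on an aromatic carbon. This carries the aryl arm of compound 3 back toward that of compound 1, so that only the ring nitrogen of the 6-ethoxypyridin-3-yl group remains as a difference from compound 1. The step from compound 1 to compound 2 bundled two changes, the ring nitrogen and the loss of ethoxy, and the data do not say how much of its size belongs to each.

Restoring ethoxy is therefore expected to recover a large part of that step; for compound 3 a marked drop in this assay is expected, a 43-fold lower number from compound 2 to compound 3 (1.64 log units; beyond the scatter). The estimate for compound 3 is 300 nM, in the range 50 nM to 2500 nM.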

Compound 3, half-maximal inhibitory concentration: 44 nM
Compound 3: middle estimate off by 6.8-fold (0.83 log units), on the high side; the measured number lies below the stated range.
By their numbers in this assay, from the lowest: compounds 1 and 3 (each within the scatter of the next); then compound 2.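

In this assay, ethoxy in place of methyl on the aromatic carbon next to the ring nitrogen gives a 300-fold lower number from compound 2 to compound 3 (2.47 log units; beyond the scatter), so this one position accounts for a change of the same order as the earlier step, a 450-fold higher number from compound 1 to compound 2 (2.65 log units; beyond the scatter). The ring nitrogen, which the earlier step could not separate from the loss of ethoxy, can now be read on its own: 6-ethoxypyridin-3-yl in place of 4-ethoxyphenyl gives a 1.5-fold higher number from compound 1 to compound 3 (0.18 log units; within the scatter), so with ethoxy present the two arms cannot be told apart in this assay, and the large loss in compound 2 goes with methyl at this position rather than with the ring nitrogen as such. Nothing at hand explains why the exchange of methyl for ethoxy has this size.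

The methyl-to-ethoxy change adds both an oxygen and a longer chain, and the compounds shown leave open which of these carries the step; methoxy, propoxy, an ethyl group or an amine at this carbon would separate them. Also open, going by these compounds, is whether methyl is as poor on the phenyl arm, which a 4-methylphenyl partner of compound 1 would show.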